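A 2-carboxyethyl chain on compound 3

The source may hold more compounds than are shown below. What is called first, only, known or untested is meant among the compounds shown, and "the series" means these compounds.

In a functional assay (trachea) with Cavia porcellus as the target (on this read-out lower numbers stand for an effect already at smaller amounts and higher numbers for an effect only at larger amounts of compound), compound 1 (`C=CCCn1c(=O)c2[nH]cnc2n(CCC)c1=O`) gives 200 nM, compound 2 (`CCCn1c(=O)n(CCOCC)c(=O)c2[nH]cnc21`) gives 70 nM, and compound 3 (`CCCn1c(=O)n(C)c(=O)c2[nH]cnc21`) gives 1600 nM, the highest number of the three. Compound 4 (`CCCn1c(=O)n(C)c(=O)c2c1ncn2CCC(=O)O`) has 2-carboxyethyl in place of hydrogen on an aromatic nitrogen. Going by the values given here, no measured compound carries a group there, so the available steps bear only indirectly. They concern a chain on a different aromatic nitrogen: an 8.0-fold higher number from compound 1 to compound 3 (0.90 log units; beyond the scatter) is modest and a 23-fold higher number from compound 2 to compound 3 (1.36 log units; beyond the scatter) is large. With that caution, a large step to a higher number is expected, namely a 6.3-fold higher number from compound 3 to compound 4 (0.80 log units; beyond the scatter). Compound 4 is estimated at 10000 nM, with an expected range of 2000 nM to 60000 nM.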

Compound 4, half-maximal effective concentration: > 100000 nM
Compound 4 was reported as a limit; the forecaster's own chance of this, stated with the estimate: 25%; middle value at least 10-fold (1.00 log units) away from the limit.
By their numbers in this assay, from the lowest: compound 2; then compound 1; then compound 3. At a limit, above all of these: compound 4.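

Putting 2-carboxyethyl in place of hydrogen on this aromatic nitrogen gives, in this assay, the first step seen at this position: an at least 62-fold higher number from compound 3 to compound 4 (1.79 log units; beyond the scatter). Compound 4 is reported only as a limit: the limit of > 100000 nM in this assay, at which 1 of the 4 values shown sits. On these data alone, the position therefore responds strongly to this change, but the full size of the step remains unknown.

As far as these compounds go, whether the rise goes with the carboxylic acid or with the chain itself remains open. A plain propyl chain, or the ethyl ester or amide of the acid, on this nitrogen would separate the two.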